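The compounds below may be only part of what the source reports. "The series", "measured", "known", "first", "only" and "open" are said of these compounds alone.

Measured so far:
compound 1 `CN(C)C(=O)c1cccnc1NCCCN1CCN(c2ccccc2O)CC1` — 63.1 nM
compound 2 `CCOc1ccccc1N1CCN(CCCNc2ncccc2C(=O)N(C)C)CC1` — 7.94 nM
compound 3 `CSc1ccccc1N1CCN(CCCNc2ncccc2C(=O)N(C)C)CC1` — 31.6 nM

In a functional assay on aorta for antagonist activity at Alpha-1D adrenergic receptor (Rattus norvegicus) (a lower number here means tighter binding, a higher number weaker binding), compound 3 stands second highest of the three numbers: its nearest neighbour is compound 1 (a 2.0-fold lower number from compound 1 to compound 3 (0.30 log units; within the scatter)), its furthest is compound 2 (a 4.0-fold higher number from compound 2 to compound 3 (0.60 log units; beyond the scatter)). Compound 4 `COc1cc(O)ccc1N1CCN(CCCNc2ncccc2C(=O)N(C)C)CC1` is not yet measured; it differs from compound 3 by 4-hydroxy-2-methoxyphenyl in place of 2-(methylsulfanyl)phenyl on an amine nitrogen in a ring. For the measured compounds named here, no measured step makes this exact change. Going by the values given here, the steps that bear on it are a 7.9-fold lower number from compound 1 to compound 2 (0.90 log units; beyond the scatter) and a 4.0-fold higher number from compound 2 to compound 3 (0.60 log units; beyond the scatter), which show that the oxygen-bearing groups on this ring gave the lower numbers. Compound 4 is therefore expected to move downward, a 2.1-fold lower number from compound 3 to compound 4 (0.32 log units; beyond the scatter), to an estimated 15 nM with a range of 4 nM to 60 nM.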

Compound 4, dissociation constant: 79.4 nM
Compound 4: the middle estimate sits 5.3-fold (0.72 log units) below what was measured, and the stated range ends below it.
By their numbers in this assay, from the lowest: compound 2; then compounds 3, 1 and 4 (each within the scatter of the next, the first and the last beyond it).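

In this assay, oxygen on this aromatic ring did not by itself give a low number: 4-hydroxy-2-methoxyphenyl in place of 2-(methylsulfanyl)phenyl gives a 2.5-fold higher number from compound 3 to compound 4 (0.40 log units; beyond the scatter), and in place of 2-ethoxyphenyl gives a 10-fold higher number from compound 2 to compound 4 (1.00 log units; beyond the scatter). In place of 2-hydroxyphenyl it gives a 1.3-fold higher number from compound 1 to compound 4 (0.10 log units; within the scatter), so the two hydroxy-bearing compounds stand within the scatter of each other. No supporting evidence explains this result. Going by these compounds, whether the hydroxy or the methoxy of compound 4 sets its number stays open, as does the effect of an amino or chloro group on this ring.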